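The source may report more compounds than this note shows. Statements on the series, on what has been measured and on what is new or still open speak of the compounds shown alone.

Of the compounds shown here, three have been measured in a functional assay on CCRF-CEM cells (Homo sapiens) for cytotoxicity, in the presence of a further agent that is not named here; a lower number here means a stronger inhibitor, a higher number a weaker inhibitor: compound 1 `COC(=O)c1ccc(CN(CCCc2c(N)nc(N)nc2O)c2cc(F)c(F)cc2[N+](=O)[O-])cc1` gives 53000 nM, compound 2 `COC(=O)c1ccc(CN(CCCc2c(N)nc(N)nc2O)c2ccc([N+](=O)[O-])c(F)c2F)cc1` gives 45000 nM, and compound 3 `CC(C)(C)OC(=O)CCC(Nc1ccc(CN(CCCc2c(N)nc(N)nc2O)c2ccc([N+](=O)[O-])c(F)c2F)cc1)C(=O)OC(C)(C)C` gives 20000 nM.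

Compound 1 and compound 2 share one core and differ only by 4,5-difluoro-2-nitrophenyl in place of 2,3-difluoro-4-nitrophenyl on an amine nitrogen, a change that made a step of a 1.2-fold higher number from compound 2 to compound 1 (0.07 log units; within the scatter). Compound 3 has another core; how it differs from compound 2 is not broken down here, but in this assay compound 3 gives the lowest number of the three. Compound 4 `CC(C)(C)OC(=O)CCC(Nc1ccc(CN(CCCc2c(N)nc(N)nc2O)c2cc(F)c(F)cc2[N+](=O)[O-])cc1)C(=O)OC(C)(C)C` has not yet been measured. It differs from compound 3 by 4,5-difluoro-2-nitrophenyl in place of 2,3-difluoro-4-nitrophenyl on an amine nitrogen, which is the same change, at the same place, as that between compound 2 and compound 1. The step from compound 3 to compound 4 is expected to be about a 1.2-fold higher number from compound 3 to compound 4 (0.08 log units; within the scatter), because the same change earlier gave a 1.2-fold higher number from compound 2 to compound 1 (0.07 log units; within the scatter). Compound 4 is therefore estimated to give 24000 nM, with a likely range from 10000 nM to 55000 nM.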

Compound 4, half-maximal inhibitory concentration: 3100 nM
Compound 4: middle estimate off by 7.7-fold (0.89 log units), on the high side; measured number below the stated range.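

In this assay, 4,5-difluoro-2-nitrophenyl in place of 2,3-difluoro-4-nitrophenyl on an amine nitrogen gave a 6.5-fold lower number from compound 3 to compound 4 (0.81 log units; beyond the scatter), so the step seen on the core of compound 2 did not carry over to the core of compound 3: the same change on two cores in this assay, a 1.2-fold higher number (0.07 log units; within the scatter) from compound 2 to compound 1 and a 6.5-fold lower number (0.81 log units; beyond the scatter) from compound 3 to compound 4, 7.6-fold (0.88 log units) apart, beyond the scatter of two such steps In this series, then, a step read on one core was no reliable guide to the same change on the other. Going by these compounds alone, with only one pair on each core, this does not show which part of the core matters, or how the change would behave on any further core.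

The compounds shown leave open whether the step seen on the core of compound 3 would persist with a carboxylic acid in place of the tert-butyl esters. They also leave open whether it would persist with a longer chain on the amine nitrogen.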